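The source may hold more compounds than are shown below. What is called first, only, known or untested is meant among the compounds shown, and "the series" means these compounds.

Compounds 1, 2 and 3 share one core and differ only in the fluoro or chloro groups on a single aromatic ring. In a functional assay on MDA-MB-231 cells (Homo sapiens) for inhibition, read by MTT assay, with a stated time of 5 days (a higher number here means a weaker inhibitor, a lower number a stronger inhibitor), compound 1 `Cc1cc(Nc2nc(NCc3ccccc3F)nc3[nH]ncc23)n[nH]1` gives 9850 nM, compound 2 `Cc1cc(Nc2nc(NCc3ccccc3Cl)nc3[nH]ncc23)n[nH]1` gives 4210 nM and compound 3 `Cc1cc(Nc2nc(NCc3ccc(F)cc3F)nc3[nH]ncc23)n[nH]1` gives 2670 nM. Compound 3 therefore shares the low end of this small range, since the data show a 1.6-fold lower number from compound 2 to compound 3 (0.20 log units; within the scatter). The chloro swap is a real but small move, at a 2.3-fold lower number from compound 1 to compound 2 (0.37 log units; beyond the scatter).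

Compound 4 `Cc1cc(Nc2nc(NCc3ccc(F)cc3F)nc3c2cnn3C2CCCCC2)n[nH]1` keeps the 2,4-difluorophenyl group and changes a different part of the molecule, with cyclohexyl in place of hydrogen on an aromatic nitrogen. Among the compounds with values here, no measured step touches that nitrogen, so the earlier steps offer only a rough guide to how far one change has moved the number. The largest of them, a 3.7-fold lower number from compound 1 to compound 3 (0.57 log units; beyond the scatter), is modest. With no direct evidence, a step of similar size is expected in this assay, leaning towards a lower number, although a higher one remains possible. The estimated change is a 2.2-fold lower number from compound 3 to compound 4 (0.35 log units; beyond the scatter). For compound 4 the expected value is 1200 nM, with an estimated range of 250 nM to 6000 nM.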

Compound 4, half-maximal inhibitory concentration: 2960 nM
Beside the measured number, compound 4's estimate is 2.5-fold (0.39 log units) below it; the range from low to high includes it.
By their numbers in this assay, from the lowest: compounds 3, 4 and 2 (each within the scatter of the next); then compound 1.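

Putting cyclohexyl on the aromatic nitrogen of the five-membered ring, where compound 3 carries only a hydrogen, leaves this assay with a 1.1-fold higher number from compound 3 to compound 4 (0.04 log units; within the scatter), so the two compounds cannot be told apart here. The earlier compounds shown here varied only the fluoro and chloro groups on a single aromatic ring, and this result adds that a position elsewhere in the molecule can carry a six-membered ring of carbon, with six more heavy atoms, without a measurable gain or loss in this read-out. No measurement available here speaks to why the number stays level.

Only one group has been shown on this nitrogen, so it remains open whether a methyl, a longer chain, a phenyl ring or a chain ending in an amine would also leave the number level. Going by these compounds, it is equally open whether cyclohexyl would behave the same way alongside the 2-fluoro or 2-chloro rings of compound 1 and compound 2, as the result stands only with the 2,4-difluorophenyl group.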